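Moving from 2-bromophenyl to 4-bromophenyl on sulfur

A few compounds are considered here, and "the series" means these few. Any claim that something is new, unique, unknown or untested is made for them only; others in the source may bear on it.

In a functional assay on DU-145 cells (Homo sapiens) for inhibition, read by trypan blue exclusion, with a stated time of 96 h (on this read-out higher numbers stand for weaker inhibition of growth and lower numbers for stronger inhibition of growth), compound 2 `O=C(/C(=C\c1ccc(O)c([N+](=O)[O-])c1)Sc1ccccc1Br)c1ccc(Br)cc1` gives 10000 nM, level with compound 1 `O=C(/C(=C\c1ccc(O)c([N+](=O)[O-])c1)SCc1ccc(Br)cc1)c1ccc([N+](=O)[O-])cc1` at 10000 nM, while compound 3 `O=C(/C(=C\c1ccc(O)c([N+](=O)[O-])c1)Sc1ccccc1Br)c1ccc(Cl)cc1` gives 25000 nM. Compound 4 `O=C(/C(=C\c1ccc(O)c([N+](=O)[O-])c1)Sc1ccc(Br)cc1)c1ccc(Br)cc1` has the same atoms as compound 2, joined differently: 4-bromophenyl in place of 2-bromophenyl on a sulfur. Among the compounds with values here, the only measured step, a 2.5-fold higher number from compound 2 to compound 3 (0.40 log units; beyond the scatter), puts chloro in place of bromo on an aromatic carbon. No bromine changes place in that step, so it offers a rough size and no direction, and no shift beyond the scatter is expected. Compound 4 is expected to give 10000 nM, with an estimated range of 4000 nM to 25000 nM. The expected change is no change at the digits printed from compound 2 to compound 4 (within the scatter).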

Compound 4, concentration for 50% growth inhibition: 1000 nM
Compound 4: middle estimate off by 10-fold (1.00 log units), on the high side, and the stated range ends above it.
By their numbers in this assay, from the lowest: compound 4; then compounds 1 and 2 (each within the scatter of the next); then compound 3.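

In this assay the step from 2-bromophenyl to 4-bromophenyl on the sulfur gives a 10-fold lower number from compound 2 to compound 4 (1.00 log units; beyond the scatter) with no atom gained or lost. Within the data shown here, the earlier step only exchanged one halogen for another, so this is the first sign that where the bromine sits on this ring can alone shift the number beyond the scatter. Nothing shown here accounts for the shift. Still open, from the compounds shown here alone, is whether bromine itself counts: a phenyl on that sulfur carrying a methoxy group or an amine instead could give a lower or a higher number.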